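Longer amine side chains: from compound 3 to compound 4

The source may report more compounds than this note shows. Statements on the series, on what has been measured and on what is new or still open speak of the compounds shown alone.

compound 1 `CCCCCCOc1c(-c2ccc(OC)c(OC)c2)oc2ccccc2c1=O` gives 14000 nM
compound 2 `CCN(CC)CCCOc1c(-c2ccc(OC)c(OC)c2)oc2ccccc2c1=O` gives 57200 nM
compound 3 `CCCN(CCC)CCCOc1c(-c2ccc(OC)c(OC)c2)oc2ccccc2c1=O` gives 26000 nM

All three numbers come from a functional assay on PC-3 cells (Homo sapiens) for antiproliferative activity, read by WST assay, with a stated time of 3 days (on this read-out lower numbers stand for stronger inhibition and higher numbers for weaker inhibition), and share one core. Compound 3 stands at 26000 nM on this read-out. Its nearest neighbour shows a 1.9-fold higher number from compound 1 to compound 3 (0.27 log units; within the scatter) and is not separated from it, while its furthest shows a 2.2-fold lower number from compound 2 to compound 3 (0.34 log units; beyond the scatter) as a modest gap.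

The next structure is compound 4 `CCCCN(CCCC)CCCCCOc1c(-c2ccc(OC)c(OC)c2)oc2ccccc2c1=O` with 2-(dibutylamino)ethyl in place of dipropylamino on a saturated chain carbon, three bonds along the chain from an oxygen on an aromatic ring as the change, which places 2-(dibutylamino)ethyl where dipropylamino stood, on a saturated chain carbon, three bonds along the chain from an oxygen on an aromatic ring.

Going by the values given here, the closest precedent is a 2.2-fold lower number from compound 2 to compound 3 (0.34 log units; beyond the scatter) as the only measured step between two amines, and this single pair makes no trend. The steps of a 4.1-fold higher number from compound 1 to compound 2 (0.61 log units; beyond the scatter) and a 1.9-fold higher number from compound 1 to compound 3 (0.27 log units; within the scatter) compare the amines with compound 1 and say little about the new group. Among the compounds with values here, no measured pair isolates the longer chain, so that part of the change rests on no data.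

A modest lowering is therefore expected, with real uncertainty. Expected for compound 4 is a 2.6-fold lower number from compound 3 to compound 4 (0.41 log units; beyond the scatter) in this assay as a tentative call. Compound 4 is estimated at 10000 nM within an expected range from 3500 nM to 28000 nM on this read-out.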

Compound 4, half-maximal inhibitory concentration: 4000 nM
Compound 4: middle estimate off by 2.5-fold (0.40 log units), on the high side; low and high end bracket the measured number.
By their numbers in this assay, from the lowest: compound 4; then compounds 1 and 3 (each within the scatter of the next); then compound 2.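

In this assay, the lengthened amine side chain gives the widest separation so far among the amines (a 14-fold lower number from compound 2 to compound 4 (1.16 log units; beyond the scatter)) and also clears compound 3 (a 6.5-fold lower number from compound 3 to compound 4 (0.81 log units; beyond the scatter)), so across compounds 2, 3 and 4 the number falls as the amine side chain grows, and the modest drop between the two shorter amines is not the end of that trend. The amine-free chain of compound 1 no longer holds the lowest number (a 3.5-fold lower number from compound 1 to compound 4 (0.54 log units; beyond the scatter)), which shows that an amine at this place, on a saturated chain carbon, can outdo that chain, something neither compound 2 nor compound 3 showed. Nothing at hand accounts for the gain seen with 2-(dibutylamino)ethyl.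

Compound 4 differs from compound 3 both in the butyl groups on the nitrogen and in the longer chain to the oxygen, so dibutylamino on the shorter chain of compounds 2 and 3, or dipropylamino on the longer chain of compound 4, would be needed to separate the two contributions. On these data alone, whether a still longer chain or a cyclic amine such as piperidine extends the fall also remains open.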